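Swapping a methyl for a hydroxy on the hanging phenyl

The source may hold more compounds than are shown below. What is called first, only, known or untested is meant among the compounds shown, and "the series" means these compounds.

Of the compounds shown here, three sharing one core have been tested so far in an ADME assay on NIH3T3 cells (Mus musculus) for cytotoxicity, read by MTT assay, with a stated time of 24 h; on this read-out higher numbers stand for weaker inhibition and lower numbers for stronger inhibition. Compound 1 `O=C(CSc1nnc(-c2ccncc2)o1)N/N=C/c1ccc([N+](=O)[O-])cc1` gives 195000 nM. Compound 2 `O=C(CSc1nnc(-c2ccncc2)o1)N/N=C/c1ccc(O)cc1` gives 158000 nM, and compound 3 `Cc1ccc(/C=N/NC(=O)CSc2nnc(-c3ccncc3)o2)cc1` gives 185000 nM. On these numbers compound 3 sits second highest of the three, but every gap is small: a 1.1-fold lower number from compound 1 to compound 3 (0.02 log units; within the scatter), a 1.2-fold lower number from compound 1 to compound 2 (0.09 log units; within the scatter) and a 1.2-fold higher number from compound 2 to compound 3 (0.07 log units; within the scatter), each inside the usual scatter of this assay, so none of the three can be called more or less toxic than another.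

The next compound, compound 4 `O=C(CSc1nnc(-c2ccncc2)o1)N/N=C/c1ccccc1O`, differs from compound 3 in one spot: 2-hydroxyphenyl in place of 4-methylphenyl on a carbon with a double bond to nitrogen. The step that bears most directly on this is the one in which a methyl replaced a hydroxy on the same ring, a 1.2-fold higher number from compound 2 to compound 3 (0.07 log units; within the scatter), which stayed within the scatter. Putting a hydroxy back, now in the 2-position of the phenyl instead of the 4-position, is therefore expected to move this assay by a 1.1-fold lower number from compound 3 to compound 4 (0.04 log units; within the scatter), that is, by nothing beyond the scatter. Among the measured compounds shown here, no measured pair shows a hydroxy in the 2-position, so this expectation rests on the 4-position pair only. Compound 4 is estimated at 170000 nM, with a likely range from 85000 nM to 340000 nM.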

Compound 4, half-maximal inhibitory concentration: 155000 nM
Beside the measured number, compound 4's estimate is 1.1-fold (0.04 log units) above it; the range from low to high includes it.
By their numbers in this assay, from the lowest: compounds 4, 2, 3 and 1 (each within the scatter of the next).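

In this assay the hydroxy now appears at a second place on the hanging phenyl, and moving it gives a 1.0-fold lower number from compound 2 to compound 4 (0.01 log units; within the scatter) with no separation between the 2-hydroxyphenyl and the 4-hydroxyphenyl. The other two comparisons on this carbon with a double bond to nitrogen tell the same story: a 1.2-fold lower number from compound 3 to compound 4 (0.08 log units; within the scatter) for 2-hydroxyphenyl against 4-methylphenyl and a 1.3-fold lower number from compound 1 to compound 4 (0.10 log units; within the scatter) for 2-hydroxyphenyl against 4-nitrophenyl, so none of the four phenyl groups shown can be told apart in this read-out, whether or not the group carries a hydroxy and wherever that hydroxy sits. Nothing available explains why these compounds read alike.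

The compounds shown leave open whether any group on this phenyl can move the read-out beyond the scatter, for example an amine, a carboxylic acid or a chlorine atom, since only hydroxy, methyl and nitro appear here. They also leave open whether the same holds with a longer chain in place of the link that joins this phenyl to the shared core.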